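Alkoxymethyl Chain Growth and Cell Inhibition on a Shared Core

The source may report more compounds than this note shows. Statements on the series, on what has been measured and on what is new or still open speak of the compounds shown alone.

Compound 1 `CCOCc1cc(CN2CCCCC2)c(O)c2ncccc12` gives 23400 nM
Compound 2 `CC(C)OCc1cc(CN2CCCCC2)c(O)c2ncccc12` gives 7410 nM
Compound 3 `COCc1cc(CN2CCC(C)CC2)c(O)c2ncccc12` gives 13800 nM

Of the compounds shown here, three have been tested in a functional assay on A-431 cells (Homo sapiens) for inhibition, with a stated time of 72 h; on this read-out higher numbers stand for weaker inhibition and lower numbers for stronger inhibition. Compound 2 differs from compound 1 by methyl in place of hydrogen on a saturated chain carbon bound to an oxygen on a saturated carbon and a saturated chain carbon, and this brought a 3.2-fold lower number from compound 1 to compound 2 (0.50 log units; beyond the scatter). Compound 3 has the same atoms as compound 1 joined differently; the difference between the two cores is not broken down here. Compound 4 `CCOCc1cc(CN2CCC(C)CC2)c(O)c2ncccc12` has not yet been measured and differs from compound 3 by methyl in place of hydrogen on a saturated chain carbon bound to an oxygen on a saturated carbon. This is the same kind of change as that from compound 1 to compound 2, although in compound 4 the carbon that gains the methyl is bound to an oxygen on a saturated carbon only, whereas in compound 2 it is bound to an oxygen on a saturated carbon and a saturated chain carbon. In this assay compound 4 is expected to show a 2.5-fold lower number from compound 3 to compound 4 (0.40 log units; beyond the scatter), because compound 2 showed a 3.2-fold lower number from compound 1 to compound 2 (0.50 log units; beyond the scatter). Compound 4 is therefore estimated at 5500 nM, with a range from 2000 nM to 15000 nM.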

Compound 4, half-maximal inhibitory concentration: 11000 nM
Compound 4: the middle estimate sits 2.0-fold (0.30 log units) below what was measured; the range from low to high includes it.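

In this assay, the same methyl in place of hydrogen gave a 1.3-fold lower number from compound 3 to compound 4 (0.10 log units; within the scatter), so on this core the change cannot be told apart from the usual scatter. Set beside the earlier step, the result does not differ from it: the same change on two cores in this assay, a 3.2-fold lower number (0.50 log units; beyond the scatter) from compound 1 to compound 2 and a 1.3-fold lower number (0.10 log units; within the scatter) from compound 3 to compound 4, 2.5-fold (0.40 log units) apart, within the scatter of two such steps. For the compounds shown here, this shows that the two cores do not demonstrably disagree, but it does not show that the change carries over with the same size, as each core offers only one pair.

Going by these compounds alone, a methyl in place of hydrogen on a saturated ring carbon gave a 2.1-fold lower number from compound 1 to compound 4 (0.33 log units; beyond the scatter), though only this one step shows that change. As far as these compounds go, whether a longer chain, such as butoxymethyl, would follow the same course on either core remains open.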